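Pyridin-4-yl for thiophen-2-yl: outlook for compound 3

The source may hold more compounds than are shown below. What is called first, only, known or untested is meant among the compounds shown, and "the series" means these compounds.

Among the measured compounds shown here, compound 2 `COc1nc(-c2cccs2)cc(-c2ccc(Cl)cc2Cl)c1C#N` gives 3280 nM in a functional assay on trachea (Cavia porcellus) for activation (a higher number here means a weaker inhibitor, a lower number a stronger inhibitor), the lowest of the two numbers measured so far; compound 1 `COc1nc(-c2ccc(Br)cc2)cc(-c2ccc(Cl)cc2Cl)c1C#N` gives 8020 nM in this assay. Compound 3 `COc1nc(-c2ccncc2)cc(-c2ccc(Cl)cc2Cl)c1C#N` carries pyridin-4-yl in place of thiophen-2-yl on an aromatic carbon. For the measured compounds named here, the only measured step at this position, a 2.4-fold lower number from compound 1 to compound 2 (0.39 log units; beyond the scatter), bears on it and shows that swapping the aryl group here moves the number modestly. Going by the values given here, no measured pair covers a thiophen-2-yl to pyridin-4-yl exchange, so a step of comparable size or none beyond the scatter is expected, a 1.2-fold higher number from compound 2 to compound 3 (0.09 log units; within the scatter). Compound 3 is estimated at 4000 nM, with a range of 1500 nM to 12000 nM.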

Compound 3, half-maximal inhibitory concentration: 11800 nM
Compound 3: middle estimate off by 3.0-fold (0.47 log units), on the low side, and the stated range covers the measured number.
By their numbers in this assay, from the lowest: compound 2; then compounds 1 and 3 (each within the scatter of the next).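

Replacing thiophen-2-yl with pyridin-4-yl gives a 3.6-fold higher number from compound 2 to compound 3 (0.56 log units; beyond the scatter) in this assay and shows that this position can separate two aryl groups of similar size. The two groups with a six-membered aromatic ring cannot be told apart, with a 1.5-fold higher number from compound 1 to compound 3 (0.17 log units; within the scatter) and thiophen-2-yl, the only five-membered aromatic ring of the three, keeps the lowest number. Nothing at hand explains these differences.

Still open, on these data alone, is whether furan-2-yl or thiophen-3-yl would match thiophen-2-yl on this carbon. Also open, as far as these compounds go, is how a non-aromatic group such as morpholine or a short alkyl chain would fare here.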